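Removing the chloro from compound 1 in the cytotoxicity series

The compounds below may be only part of what the source reports. "The series", "measured", "known", "first", "only" and "open" are said of these compounds alone.

Measured so far:
compound 1, `Cc1cc(C)n2nc(SCc3cc(=O)c4cc(Cl)ccc4o3)nc2n1`: > 25000 nM
compound 2, `Cc1nnc(SCc2coc3ccc(Cl)cc3c2=O)s1`: 13400 nM

Both compounds were run in a functional assay on MCF7 cells (Homo sapiens) for cytotoxicity, read by MTT assay, with a stated time of 72 h; a higher number here means a weaker inhibitor, a lower number a stronger inhibitor. Compound 1 gives only a limit there, > 25000 nM, so its true value is not known. Compound 2 gives 13400 nM in this assay. Going by the values given here, these two compounds differ in more than one place, so no single step between them can be defined; their values show only that compound 1 sits at the limit of > 25000 nM in this assay, at which 1 of the 2 values shown sits, while compound 2 returns a number.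

The next compound, compound 3, `Cc1cc(C)n2nc(SCc3cc(=O)c4ccccc4o3)nc2n1`, differs from compound 1 by hydrogen in place of chloro on an aromatic carbon. Because compound 1 stands at the limit (the limit of > 25000 nM in this assay, at which 1 of the 2 values shown sits), no direction for this change can be read from the measured pair. The step that the limit leaves unreadable from compound 1 to compound 3 is expected to be none beyond the scatter. Compound 3 is therefore estimated at 30000 nM, with a range from 10000 nM to 90000 nM, and a fair chance that only a limit is reported.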

Compound 3, half-maximal inhibitory concentration: > 25000 nM
Compound 3: a limit, no number (the forecaster's own chance of this, stated with the estimate: 60%); the middle value lies beyond the limit too.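

No step can be read from compound 1 to compound 3, because both return only a limit: the limit of > 25000 nM in this assay, at which 2 of the 3 values shown sit.

The compounds shown leave open whether hydrogen in place of chloro on an aromatic carbon changes the read-out in this assay at all, and where the true values of compound 1 and compound 3 lie.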